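Removing the chloro from the thiophene amide

This account rests on a few compounds, and the source may have more. Where it says the series, first, only, none or still open, it means among the compounds named here.

Three compounds sharing one core were tested in a functional assay on the whole organism (strain Wistar) for inhibition, with Rattus norvegicus as the target, read by paw edema, with stated times of 30 min and 3 h, at a dose of 20 mg/kg; on this read-out higher numbers stand for more inhibition at the one dose given (going by the name of the read-out) and lower numbers for less inhibition:
Compound 1 `CCOC(=O)C1=C(C)NC(C)=C(C(=O)OCC)C1c1ccc(OCC(=O)Nc2nc3ccccc3s2)cc1` gives 65.9%.
Compound 2 `CCOC(=O)C1=C(C)NC(C)=C(C(=O)OCC)C1c1ccc(OCC(=O)NNC(=O)c2ccc(C)cc2)cc1` gives 47.3%.
Compound 3 `CCOC(=O)C1=C(C)NC(C)=C(C(=O)OCC)C1c1ccc(OCC(=O)NNC(=O)c2sccc2Cl)cc1` gives 56.3%.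

Compound 3 stands second highest of the three numbers, but its distances to both neighbours are small: the step of a number 9.6 percentage points lower from compound 1 to compound 3 (within the scatter) and the step of a number 9 percentage points higher from compound 2 to compound 3 (within the scatter) both lie within the scatter of repeated measurements, so these three values cannot be placed in a firm order. For the measured compounds named here, only the step of a number 18.6 percentage points lower from compound 1 to compound 2 (beyond the scatter) reaches beyond the scatter.

Compound 4 `CCOC(=O)C1=C(C)NC(C)=C(C(=O)OCC)C1c1ccc(OCC(=O)NNC(=O)c2cccs2)cc1` has not yet been measured. It differs from compound 3 by a single change: hydrogen in place of chloro on an aromatic carbon. Going by the values given here, none of the measured steps adds or removes a chloro; the nearest comparison is the step of a number 9 percentage points higher from compound 2 to compound 3 (within the scatter), which exchanged the whole aromatic ring on the carbonyl carbon and still stayed within the scatter. A change as small as one chlorine for a hydrogen is therefore expected to give no step beyond the scatter in this assay. The step of a number 4.3 percentage points lower from compound 3 to compound 4 (within the scatter) implied by this estimate is expected to be essentially flat. Compound 4 is estimated at 52%, with a range from 40% to 64%.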

Compound 4, a percentage reported as inhibition, in the whole organism at one dose (the size of the read-out at that dose, not a potency): 61.1%
Estimate against measurement, compound 4: 9.1 percentage points below; the measured number falls inside the stated range.
By their numbers in this assay, from the lowest: compounds 2, 3, 4 and 1 (each within the scatter of the next, the first and the last beyond it).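

In this assay, for the compounds shown here, the chloro on the thiophene is tested directly for the first time, and replacing it with hydrogen gives a number 4.8 percentage points higher from compound 3 to compound 4 (within the scatter), so at this dose the data show no need for a chloro on this aromatic carbon next to the ring atom that bears a large group. The chloro-free ring also sharpens the comparison with the 4-methylphenyl group: a number 13.8 percentage points higher from compound 2 to compound 4 (beyond the scatter) is a modest difference that can be read, whereas the chlorinated ring gave only a number 9 percentage points higher from compound 2 to compound 3 (within the scatter), which could not separate the two. The comparison with the benzothiazole amide gives a number 4.8 percentage points lower from compound 1 to compound 4 (within the scatter), so thiophen-2-yl on the carbonyl carbon keeps compound 4 indistinguishable from compound 1 in this assay.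

Nothing measured here explains why these numbers fall as they do. On these data alone, a bromo, a methyl, a methoxy or an amine on the same ring carbon remains open, as does whether the small gap between the chloro and hydrogen compounds would hold at other doses.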